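The source may report more compounds than this note shows. Statements on the series, on what has been measured and on what is new or still open speak of the compounds shown alone.

Among the compounds with values here, compound 2 `NS(=O)(=O)NCCC1CCN(c2cc(-c3cccc(Cl)c3)ncn2)CC1` is one of two compounds measured in a functional assay on MCF7 cells (Homo sapiens) for antiproliferative activity, read by sulforhodamine B assay, with a stated time of 48 h (a higher number here means a weaker inhibitor of growth, a lower number a stronger inhibitor of growth), where compound 2 gives 31200 nM. Within the data shown here, its only neighbour, compound 1 `NS(=O)(=O)NCCC1CCN(c2cc(-c3ccccc3)ncn2)CC1`, gives 53200 nM in this assay, and the step of a 1.7-fold lower number from compound 1 to compound 2 (0.23 log units; within the scatter) means the two cannot be told apart. Compound 3 `NS(=O)(=O)NCCC1CCN(c2cc(-c3ccccc3F)ncn2)CC1` differs from compound 2 by 2-fluorophenyl in place of 3-chlorophenyl on an aromatic carbon. Among the measured compounds shown here, no measured step exchanges one substituted phenyl for another, and the single step known, a 1.7-fold lower number from compound 1 to compound 2 (0.23 log units; within the scatter), was small, so no step beyond the scatter is expected: a 1.3-fold higher number from compound 2 to compound 3 (0.11 log units; within the scatter). Compound 3 is therefore estimated at 40000 nM, with a range from 15000 nM to 110000 nM.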

Compound 3, concentration for 50% growth inhibition: > 100000 nM
Compound 3: no number, only a limit (the forecaster's own chance of this, stated with the estimate: 10%); middle value at least 2.5-fold (0.39 log units) away from the limit.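

In this assay compound 3 gives > 100000 nM, which is a limit and not a number. Exchanging one substituted phenyl for another at this position can therefore matter: 2-fluorophenyl in place of 3-chlorophenyl gives an at least 3.2-fold higher number from compound 2 to compound 3 (0.50 log units; beyond the scatter), the only step shown beyond the scatter, while fluoro in place of hydrogen gives an at least 1.8-fold higher number from compound 1 to compound 3 (0.27 log units; that floor lies within the scatter). The full size of both steps cannot be read, because the result for compound 3 is only a limit: the limit of > 100000 nM in this assay, at which 1 of the 3 values shown sits.

Going by these compounds, whether the change comes from the fluorine itself or from where it sits on the phenyl stays open. So does how an amine or a methoxy group on that phenyl would read in this assay.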